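The source may report more compounds than this note shows. Statements on the series, on what has been measured and on what is new or still open speak of the compounds shown alone.

Going by the values given here, compound 1, `CC1=C(C(=O)CC(C)C)C(c2ccco2)NC(=O)N1`, gives 31% in an assay on membranes from HeLa cells for displacement of a labelled ligand from adenosine receptor A3 (Homo sapiens), read by scintillation counting, with a stated time of 180 min, tested at 1 uM (on this read-out lower numbers stand for less inhibition and higher numbers for more inhibition at the one concentration tested (going by the name of the read-out)), the higher of the two numbers measured so far. Compound 2, `CC1=C(C(=O)CC(C)C)C(c2ccoc2)NC(=O)N1`, gives 18%; the step of a number 13 percentage points lower from compound 1 to compound 2 (beyond the scatter) concerns a furan position, not the group under study here. Compound 3, `CCSC(=O)C1=C(C)NC(=O)NC1c1ccco1`, differs from compound 1 by ethylsulfanyl in place of isobutyl on a carbonyl carbon. No measured step involves this change, so nothing shown bears directly on it; the expectation is therefore a step of a number 6 percentage points lower from compound 1 to compound 3 (within the scatter) with wide uncertainty. Compound 3 is estimated at 25%, expected between 5% and 50%.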

Compound 3, a percentage reported as inhibition, at one concentration (the size of the read-out at that concentration, not a potency): 14%
Compound 3: the middle estimate sits 11 percentage points above what was measured; measured number inside the range.
By their numbers in this assay, from the lowest: compounds 3 and 2 (each within the scatter of the next); then compound 1.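

In this assay, going by these compounds alone, the change on the carbonyl carbon gives a number 17 percentage points lower from compound 1 to compound 3 (beyond the scatter), the first measured step at this position. It shows that the read-out responds to the group on this carbon, and that ethylsulfanyl gives a lower number here than isobutyl.

Still open, from the compounds shown here alone, is how an ethoxy group, an amine such as ethylamino, or a longer chain on this carbonyl carbon would compare, and whether the step would hold with furan-3-yl in place of furan-2-yl. No measurement at hand explains this step.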